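A few compounds are considered here, and "the series" means these few. Any claim that something is new, unique, unknown or untested is made for them only; others in the source may bear on it.

In a functional assay on Hep 3B2 cells (Homo sapiens) for antiproliferative activity, read by MTT assay, with a stated time of 24 h (a lower number here means a stronger inhibitor, a higher number a weaker inhibitor), compound 1 `Cc1ccc2nc(C(=O)Nc3c(F)cc(-c4cccc(F)c4)cc3F)c(C)c(O)c2c1` gives > 100000 nM, which is a limit of the assay and not a number. Compound 2 `Cc1c(C(=O)Nc2c(F)cc(-c3cccc(F)c3)cc2F)nc2ccc(C(F)(F)F)cc2c1O` gives 29900 nM and compound 3 `Cc1ccc2nc(C(=O)Nc3c(F)cc(-c4cccc(F)c4)cc3F)c(C)c(C(=O)O)c2c1` gives 31600 nM, so these two values lie within the usual scatter of each other. Compound 3 therefore stands level with compound 2, and both have measured numbers, unlike compound 1.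

Compound 4 `COc1ccc2nc(C(=O)Nc3c(F)cc(-c4cccc(F)c4)cc3F)c(C)c(C(=O)O)c2c1` keeps everything in compound 3 except one group, with methoxy in place of methyl on an aromatic carbon. Among the measured compounds shown here, no measured pair makes this exact swap. The closest guide is a change at the same methyl, trifluoromethyl in place of methyl, which gave an at least 3.3-fold lower number from compound 1 to compound 2 (0.52 log units; beyond the scatter). The other step, carboxy in place of hydroxy, gave an at least 3.1-fold lower number from compound 1 to compound 3 (0.50 log units; beyond the scatter), but it concerns a different group and says little about the methyl. Both steps start from a limit, so they fix only a minimum size, and both were made with a hydroxy or methyl setting unlike the exact pair here.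

With so little to go on, no step beyond the scatter is expected, and the expected change is a 1.1-fold lower number from compound 3 to compound 4 (0.02 log units; within the scatter). For compound 4 the estimated value is 30000 nM, with an expected range from 10000 nM to 90000 nM.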

Compound 4, half-maximal inhibitory concentration: 14300 nM
For compound 4 the middle estimate is 2.1-fold (0.32 log units) above the measured one, within the range that was stated.
By their numbers in this assay, from the lowest: compound 4; then compounds 2 and 3 (each within the scatter of the next). At a limit, above all of these: compound 1.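

Methoxy in place of methyl, on an aromatic carbon of the six-membered aromatic ring of carbon only, gives a 2.2-fold lower number from compound 3 to compound 4 (0.34 log units; beyond the scatter), and this is the only step shown at this position with a measured number at both ends, so its size is known and not just a minimum. The earlier step at the same methyl, an at least 3.3-fold lower number from compound 1 to compound 2 (0.52 log units; beyond the scatter), starts from a limit and was made with a hydroxy group in the core, whereas this one shows that the position still responds to a change of group when a carboxy group stands in place of that hydroxy. Nothing measured here accounts for the size of this step.

As far as these compounds go, only methyl, trifluoromethyl and methoxy appear at this position, so it remains open whether a chlorine atom, an amine or a longer chain such as ethoxy would give a lower or a higher number in this assay. From the compounds shown here alone, it is also open whether methoxy would give a step of similar size with the hydroxy group of compound 1 in place of the carboxy group, and how trifluoromethyl would compare with methoxy on the carboxy-bearing core.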